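Notes on the amide substituent, compound 2 to compound 3

The compounds below may be only part of what the source reports. "The series", "measured", "known", "first", "only" and "open" are said of these compounds alone.

- compound 1 `Cc1c(C(=O)Nc2ccc(Cl)cn2)nn(C)c1-c1ccc(F)cc1`: > 5 h (a limit, not a number)
- compound 2 `Cc1nc(C(=O)Nc2cccc(F)n2)c(C)n1-c1ccc(F)cc1`: 1.6 h

Both compounds were read in an ADME assay on microsomes from liver (Homo sapiens) for metabolic stability; on this read-out higher numbers stand for a longer-lived compound and lower numbers for a shorter-lived compound. Compound 1 sits at a limit of the assay, > 5 h. Among the compounds with values here, compound 2, at 1.6 h, holds the only actual number so far. Within the data shown here, the two compounds differ in more than one place, and no measured pair isolates a single change.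

The next compound is compound 3 `Cc1nc(C(=O)Nc2ccnc(Cl)n2)c(C)n1-c1ccc(F)cc1`, which differs from compound 2 at one place: 2-chloropyrimidin-4-yl in place of 6-fluoropyridin-2-yl on an amide-type nitrogen. The change is 2-chloropyrimidin-4-yl in place of 6-fluoropyridin-2-yl on an amide-type nitrogen.

Among the measured compounds shown here, with no measured step to draw on, the expectation in this assay is a modest shift towards a shorter half-life, one that may not clear the usual scatter. It is anchored on compound 2 at 1.6 h. The expected change is a 1.6-fold lower number from compound 2 to compound 3 (0.20 log units; within the scatter). For compound 3 the estimated half-life is 1 h, with an expected range of 0.4 h to 2.5 h.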

Compound 3, half-life: 4.72 h
Beside the measured number, compound 3's estimate is 4.7-fold (0.67 log units) below it; the measured number lies above the stated range.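

Within the data shown here, the amide-type nitrogen now gives the first single-place step: in this assay, 2-chloropyrimidin-4-yl in place of 6-fluoropyridin-2-yl gives a 3.0-fold higher number from compound 2 to compound 3 (0.47 log units; beyond the scatter). The half-life on this read-out therefore responds to the choice of six-membered aromatic ring at this position, on the core shared by compound 2 and compound 3, and the size of the step is not lost in the scatter. A further rise from this position may be hard to read, as compound 1 stands at a limit and not a number: the limit of > 5 h in this assay, at which 1 of the 3 values shown sits.

The chlorine and the second ring nitrogen enter together in this one change, and the compounds shown do not separate their contributions, nor do they show whether the step carries over to the core of compound 1. A 6-chloropyridin-2-yl group or a 2-methoxypyrimidin-4-yl group on the same amide-type nitrogen would bear directly on the first of these questions.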